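The source may hold more compounds than are shown below. What is called first, only, known or untested is meant among the compounds shown, and "the series" means these compounds.

Working notes on the series. Compound 1 `CC(=O)N[C@H]1[C@@H](OCCCCc2ccccc2)O[C@H](CO)[C@@H](O)[C@@H]1O`, compound 2 `CCCCCCCCCCCCCCCCO[C@H]1O[C@H](CO)[C@@H](O)[C@H](O)[C@H]1NC(C)=O` and compound 3 `C=CCCC(=O)N[C@H]1[C@@H](OCCc2ccccc2)O[C@H](CO)[C@@H](O)[C@@H]1O` share a core and differ in the chain on oxygen and the acyl group on nitrogen. In a functional assay on A-375 cells (Homo sapiens), read by thymidine incorporation (on this read-out lower numbers stand for stronger inhibition and higher numbers for weaker inhibition), compound 1 gives only a limit, > 50 uM. Compound 3 likewise gives only a limit, > 50 uM. Going by the values given here, compound 2 gives 29.3 uM, the single number among the three, the other two values sitting at the limit of > 50 uM in this assay, at which 2 of the 3 values shown sit. Compound 4 `C=CCCC(=O)N[C@H]1[C@@H](OCCCCCCCCCCCCCCCC)O[C@H](CO)[C@@H](O)[C@@H]1O` is not yet measured; it differs from compound 2 by allyl in place of hydrogen on a saturated chain carbon bound to a carbonyl carbon. Among the compounds with values here, no measured pair shows this change, so its size in this assay cannot be read from the series; a step within the scatter, in either direction, is expected. Compound 4 is estimated at 30 uM, within 12 uM to 75 uM. This corresponds to an expected step of a 1.0-fold higher number from compound 2 to compound 4 (0.01 log units; within the scatter).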

Compound 4, concentration for 50% inhibition: > 50 uM
Compound 4: no number, only a limit; the forecaster's own chance of this, stated with the estimate: 35%; middle value at least 1.6-fold (0.22 log units) from the limit.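

Going by these compounds alone, this is the first measured pair for this change: with allyl in place of hydrogen on a saturated chain carbon bound to a carbonyl carbon, this assay shows an at least 1.7-fold higher number from compound 2 to compound 4 (0.23 log units; that floor lies within the scatter). Compound 4 gives only a limit, so only a floor for the step can be read, not its size. Compound 2 remains the only compound with a number, and the series now sits largely at one value: the limit of > 50 uM in this assay, at which 3 of the 4 values shown sit.

From the compounds shown here alone, whether the step really exceeds the scatter stays open. Also open, going by these compounds, is how an amine, a carboxylic acid or a longer chain at this place would read.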